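A few compounds are considered here, and "the series" means these few. Any claim that something is new, unique, unknown or untested is made for them only; others in the source may bear on it.

In a functional assay on DLD-1 cells (Homo sapiens) for antiproliferative activity, read by MTT assay, with a stated time of 72 h (a lower number here means a stronger inhibitor, a higher number a weaker inhibitor), compound 1 `COc1ccc(-c2cn(Cc3ccccc3)nn2)cc1` gives 139000 nM, which already places it among weak inhibitors. Compound 2 `C1=C(c2cn(Cc3ccccc3)nn2)CCCC1` returns only a limit of the assay, > 100000 nM, so its value sits at the limit of > 100000 nM in this assay, at which 1 of the 2 values shown sits, and nothing more is known than that it is a weak inhibitor. Compound 3 `CCCCc1cn(Cc2ccccc2)nn1` has not yet been measured. It differs from compound 2 in one place, (butyl in place of cyclohex-1-en-1-yl on an aromatic carbon), that is, butyl in place of cyclohex-1-en-1-yl on an aromatic carbon. Among the measured compounds shown here, no step between two measured numbers exists in this set, so the expectation rests only on the two weak values of compound 1 and compound 2. From compound 2 to compound 3 no step beyond the usual scatter is expected in this assay, and the result may again be only a limit. Compound 3 is estimated at 150000 nM, within a range from 50000 nM to 500000 nM. The expected step from compound 2 to compound 3 is a step that the limit leaves unreadable from compound 2 to compound 3.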

Compound 3, half-maximal inhibitory concentration: > 100000 nM
Compound 3: only a limit was reported; the forecaster's own chance of this, stated with the estimate: 65%; the middle value lies beyond the limit too.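

Compound 2 and compound 3 both return only a limit in this assay, so no step can be read between them: the limit of > 100000 nM in this assay, at which 2 of the 3 values shown sit. The compounds shown leave open whether butyl or cyclohex-1-en-1-yl on that aromatic carbon gives the stronger inhibitor.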